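Triazole amine series: cyclohexyl for phenethyl, compound 4

This account rests on a few compounds, and the source may have more. Where it says the series, first, only, none or still open, it means among the compounds named here.

Compound 1 `CN(Cc1cn(CC(O)COC(=O)c2ccccc2)nn1)CC1CCCCC1`, compound 2 `CN(CCCc1ccccc1)Cc1cn(C2CCCCC2OC(=O)COc2ccccc2)nn1` and compound 3 `CN(CCCc1ccccc1)Cc1cn(CC(O)COC(=O)c2ccccc2)nn1` have been tested in an assay on nucleic acid for inhibition of Nucleic Acid, read by fluorescence, tested at 100 uM; on this read-out higher numbers stand for more inhibition at the one concentration tested (going by the name of the read-out) and lower numbers for less inhibition. Compound 3 gives 12%, compound 1 gives 6%, and compound 2 gives 42%, the highest of the three, both other numbers lying lower by more than the scatter. The difference between the cores of compound 2 and compound 3 is not broken down here. The change cyclohexyl in place of phenethyl on a saturated chain carbon bound to an amine nitrogen made the step of a number 6 percentage points lower from compound 3 to compound 1 (within the scatter). Compound 4 `CN(Cc1cn(C2CCCCC2OC(=O)COc2ccccc2)nn1)CC1CCCCC1` is not yet measured; it carries the same change on compound 2, (cyclohexyl in place of phenethyl on a saturated chain carbon bound to an amine nitrogen), at a place described in the same words. Because the earlier step of a number 6 percentage points lower from compound 3 to compound 1 (within the scatter) stayed within the scatter, the step from compound 2 to compound 4 is expected to be small, a number 6 percentage points lower from compound 2 to compound 4 (within the scatter). Compound 4 is therefore estimated at 36% in this assay, with a range from 20% to 50%.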

Compound 4, a percentage reported as inhibition, at one concentration (the size of the read-out at that concentration, not a potency): 37%
Compound 4: the middle estimate sits 1 percentage points below what was measured; the range from low to high includes it.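

In this assay cyclohexyl in place of phenethyl on a saturated chain carbon bound to an amine nitrogen gives a number 5 percentage points lower from compound 2 to compound 4 (within the scatter) on the core of compound 2 as well. The two cores give the same picture for this change: the same change on two cores in this assay, a number 6 percentage points lower (within the scatter) from compound 3 to compound 1 and a number 5 percentage points lower (within the scatter) from compound 2 to compound 4, 1 percentage points apart, within the scatter of two such steps.
This supports carrying the change between these two cores only, where it leaves the read-out within the scatter; it does not show that the same would hold on any other core, and it gives no ranking of cyclohexyl against phenethyl.

Still open, as far as these compounds go, is how a more distant replacement at this place would read, such as a carboxylic acid, an amide or a shorter chain. Also open, from the compounds shown here alone, is whether the small step holds on a third core.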